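Aryl amine swaps in a cytotoxicity series

The source may report more compounds than this note shows. Statements on the series, on what has been measured and on what is new or still open speak of the compounds shown alone.

Compound 1 `CCS(=O)(=O)Nc1cc(-c2ccc3ncnc(Nc4ccc(F)cc4)c3c2)cnc1OC` gives 1470 nM in a functional assay on SK-HEP1 cells (Homo sapiens) for cytotoxicity, read by sulforhodamine B assay, with a stated time of 72 h; on this read-out lower numbers stand for stronger inhibition and higher numbers for weaker inhibition. Compound 2 `CCS(=O)(=O)Nc1cc(-c2ccc3ncnc(Nc4ccc(OC)cc4)c3c2)cnc1OC` carries methoxy in place of fluoro on an aromatic carbon and gives 1610 nM, so the step of a 1.1-fold higher number from compound 1 to compound 2 (0.04 log units; within the scatter) is flat. Compound 3 `CCS(=O)(=O)Nc1cc(-c2ccc3ncnc(Nc4ccc(F)nc4)c3c2)cnc1OC` differs from compound 1 by 6-fluoropyridin-3-yl in place of 4-fluorophenyl on a nitrogen on an aromatic ring; in this assay compound 3 gives 5240 nM, with a 3.6-fold higher number from compound 1 to compound 3 (0.55 log units; beyond the scatter) and a 3.3-fold higher number from compound 2 to compound 3 (0.51 log units; beyond the scatter) both beyond the scatter. Compound 4 `CCS(=O)(=O)Nc1cc(-c2ccc3ncnc(Nc4ccc(OC)nc4)c3c2)cnc1OC` is not yet measured and carries methoxy in place of fluoro on an aromatic carbon, the same kind of change as from compound 1 to compound 2; the surroundings differ in that the ring now has 1 nitrogen and the group sits next to the ring nitrogen, rather than on a ring of carbon only. The step from compound 3 to compound 4 is expected to be a 1.0-fold higher number from compound 3 to compound 4 (0.02 log units; within the scatter), resting on the flat step a 1.1-fold higher number from compound 1 to compound 2 (0.04 log units; within the scatter) of compound 1. Compound 4 is therefore estimated at 5500 nM, between 2500 nM and 12000 nM.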

Compound 4, half-maximal inhibitory concentration: 3440 nM
The estimate for compound 4 lay 1.6-fold (0.20 log units) above the measured number; the range from low to high includes it.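

In this assay, the swap of fluoro for methoxy behaves alike on both aryl groups: the same change on two cores in this assay, a 1.1-fold higher number (0.04 log units; within the scatter) from compound 1 to compound 2 and a 1.5-fold lower number (0.18 log units; within the scatter) from compound 3 to compound 4, 1.7-fold (0.22 log units) apart, within the scatter of two such steps

The step of a 1.5-fold lower number from compound 3 to compound 4 (0.18 log units; within the scatter) stays flat, while the ring nitrogen still separates the methoxy compounds and the fluoro-to-methoxy pair across aryl groups, with a 2.1-fold higher number from compound 2 to compound 4 (0.33 log units; beyond the scatter) and a 2.3-fold higher number from compound 1 to compound 4 (0.37 log units; beyond the scatter), both modest. This rests on a single pair per core in one cell assay, so it supports transfer of this one change between these two cores only and gives no reason for it.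

Open, on these data alone, is whether an amine or a longer chain such as ethoxy in this place on the ring stays equally flat. Also open, as far as these compounds go, is whether the flat result holds for a carboxylic acid there.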